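The source may hold more compounds than are shown below. What is called first, only, known or untested is meant among the compounds shown, and "the series" means these compounds.

Measured compounds:
- compound 1 `CONC(=O)c1ccc(N(Cc2ccc(C3CCCCC3)cn2)C(=O)[C@H]2CCN2S(=O)(=O)c2c(F)c(F)c(F)c(F)c2F)cc1O`: 6700 nM
- compound 2 `O=C([C@H]1CCN1S(=O)(=O)c1c(F)c(F)c(F)c(F)c1F)N(Cc1cnc(C2CCCCC2)cn1)c1ccc2c(=O)[nH]ncc2c1`: 4800 nM

In a functional assay on MDA-MB-231 cells (Homo sapiens) for antiproliferative activity, with a stated time of 72 h (on this read-out lower numbers stand for an effect already at smaller amounts and higher numbers for an effect only at larger amounts of compound), compound 1 gives 6700 nM, the higher of the two numbers, while compound 2 gives 4800 nM; the gap between them lies within the scatter, so neither stands apart. Compound 3 `O=C([C@H]1CCN1S(=O)(=O)c1c(F)c(F)c(F)c(F)c1F)N(Cc1ccc(C2CCCCC2)cn1)c1cc2[nH]ncc2cc1F` differs from compound 1 at one place: 5-fluoro-1H-indazol-6-yl in place of 3-hydroxy-4-(methoxycarbamoyl)phenyl on an amide-type nitrogen. Going by the values given here, no step of a similar kind is available among the measured pair, so the expected size of the step rests only on the two values at hand, which sit close together. Compound 3 is expected to give 5000 nM (range 1500 nM to 20000 nM), a step of a 1.3-fold lower number from compound 1 to compound 3 (0.13 log units; within the scatter) that is expected to stay within the scatter.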

Compound 3, half-maximal effective concentration: 2300 nM
For compound 3 the middle estimate is 2.2-fold (0.34 log units) above the measured one, within the range that was stated.
By their numbers in this assay, from the lowest: compound 3; then compounds 2 and 1 (each within the scatter of the next).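

In this assay, going by these compounds alone, placing 5-fluoro-1H-indazol-6-yl instead of 3-hydroxy-4-(methoxycarbamoyl)phenyl on the amide-type nitrogen gives a 2.9-fold lower number from compound 1 to compound 3 (0.46 log units; beyond the scatter) and thus the first step beyond the scatter at this position. The read-out therefore responds to the group at this place, and the entering group, with one hydrogen-bond donor and one acceptor, keeps the activity measurable. Nothing available explains why the number falls. From the compounds shown here alone, it remains open whether the fluorine or the two-ring group carries the step. Also open, going by these compounds, is how an amine or a carboxylic acid would behave at this place.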